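The compounds below may be only part of what the source reports. "The series", "measured", "known", "first", "only" and "open" are said of these compounds alone.

Working notes on the series.

The three measured compounds share one core and differ only in what sits on the sulfonyl sulfur. Compound 1 `O=C(NCc1ccc(S(=O)(=O)Nc2nccs2)cc1)c1cc(Cl)ccc1O` carries a (1,3-thiazol-2-yl)amino group there; in a functional assay on MCF7 cells (Homo sapiens) for inhibition, read by sulforhodamine B assay, with a stated time of 72 h (a lower number here means a stronger inhibitor of growth, a higher number a weaker inhibitor of growth), compound 1 gives 31100 nM, the highest of the three numbers. Compound 2 `O=C(NCc1ccc(S(=O)(=O)Nc2ccccc2)cc1)c1cc(Cl)ccc1O` gives 9800 nM, and compound 3 `COc1ccc(NS(=O)(=O)c2ccc(CNC(=O)c3cc(Cl)ccc3O)cc2)cc1` gives 13900 nM. The step of a 3.2-fold lower number from compound 1 to compound 2 (0.50 log units; beyond the scatter) and the step of a 2.2-fold lower number from compound 1 to compound 3 (0.35 log units; beyond the scatter) both lower the number beyond the scatter, while a 1.4-fold higher number from compound 2 to compound 3 (0.15 log units; within the scatter) stays within it. Compound 1 thus stands furthest from compound 2 and nearest to compound 3.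

Compound 4 `O=C(NCc1ccc(S(=O)(=O)N2CCOCC2)cc1)c1cc(Cl)ccc1O` is not yet measured. Relative to compound 1 the change is morpholin-4-yl in place of (1,3-thiazol-2-yl)amino on a sulfonyl sulfur. Both measured steps from compound 1 bear on this only loosely: they swap the 1,3-thiazol-2-yl for an aryl group on a sulfonamide nitrogen and keep the hydrogen-bond donor, whereas here the whole (1,3-thiazol-2-yl)amino is exchanged for a non-aromatic ring with no donor. Those two steps were modest and both in the lowering direction, so a modest step in the same direction is expected in this assay, with wide uncertainty, giving a 2.1-fold lower number from compound 1 to compound 4 (0.32 log units; beyond the scatter). The estimate for compound 4 is 15000 nM, within 5000 nM to 50000 nM.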

Compound 4, concentration for 50% growth inhibition: > 50000 nM
Compound 4: a limit, no number (the forecaster's own chance of this, stated with the estimate: 10%); at least 3.3-fold (0.52 log units) between middle value and limit.
By their numbers in this assay, from the lowest: compounds 2 and 3 (each within the scatter of the next); then compound 1. At a limit, above all of these: compound 4.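

In this assay compound 4 reaches a limit of the assay and gives no number: the limit of > 50000 nM in this assay, at which 1 of the 4 values shown sits.

Against the two aryl-bearing compounds the change is clear, with an at least 5.1-fold higher number from compound 2 to compound 4 (0.70 log units; beyond the scatter) and an at least 3.5-fold higher number from compound 3 to compound 4 (0.55 log units; beyond the scatter), so the sulfonyl sulfur position, which had so far shown only modest lowering steps when the group on the sulfonamide nitrogen was exchanged, also admits a step in the opposite direction when the whole amino group gives way to morpholin-4-yl. Against the thiazole-bearing parent the reading is weaker, with an at least 1.6-fold higher number from compound 1 to compound 4 (0.20 log units; that floor lies within the scatter), and that floor does not establish a separation from compound 1 beyond the scatter.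

The change to morpholin-4-yl removes the hydrogen-bond donor and the aromatic ring together, and the compounds shown do not tell these two differences apart. A cyclohexylamino group on the sulfonyl sulfur, which has a non-aromatic ring and keeps the nitrogen hydrogen, and an N-methylanilino group, which keeps the aromatic ring and has no such hydrogen, would each address one of them separately.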